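Adenosine A2b binding notes: aryl piperazine sulfonamide xanthines

This account rests on a few compounds, and the source may have more. Where it says the series, first, only, none or still open, it means among the compounds named here.

Measured compounds:
- compound 1 `CCCn1c(=O)[nH]c2nc(-c3ccc(S(=O)(=O)N4CCN(c5cccc(F)c5)CC4)cc3)[nH]c2c1=O`: 0.632 nM
- compound 2 `CCCn1c(=O)[nH]c2nc(-c3ccc(S(=O)(=O)N4CCN(c5ccc(Br)cc5)CC4)cc3)[nH]c2c1=O`: 0.0835 nM
- compound 3 `CCCn1c(=O)[nH]c2nc(-c3ccc(S(=O)(=O)N4CCN(c5ccc(I)cc5)CC4)cc3)[nH]c2c1=O`: 0.159 nM

Three compounds share a core and differ only in the aryl group on the amine nitrogen of the ring. In an assay on CHO cells for displacement of a labelled ligand from adenosine receptor A2b (Homo sapiens), read by scintillation counting, with a stated time of 75 min, in the presence of a further agent that is not named here (on this read-out higher numbers stand for weaker inhibition and lower numbers for stronger inhibition), compound 1 gives 0.632 nM, compound 2 gives 0.0835 nM and compound 3 gives 0.159 nM. Compound 3 stands second highest of the three numbers; a 1.9-fold higher number from compound 2 to compound 3 (0.28 log units; within the scatter), within the scatter, while a 4.0-fold lower number from compound 1 to compound 3 (0.60 log units; beyond the scatter), beyond it.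

Compound 4 `CCCn1c(=O)[nH]c2nc(-c3ccc(S(=O)(=O)N4CCN(c5cccc(Cl)c5)CC4)cc3)[nH]c2c1=O` is not yet measured. The change from compound 3 is 3-chlorophenyl in place of 4-iodophenyl on an amine nitrogen in a ring

Among the compounds with values here, the steps that bear on this are a 4.0-fold lower number from compound 1 to compound 3 (0.60 log units; beyond the scatter) and a 7.6-fold lower number from compound 1 to compound 2 (0.88 log units; beyond the scatter): both 4-halophenyl groups gave lower numbers than 3-fluorophenyl. Compound 4 carries a 3-chlorophenyl, so the step is expected to run the other way, toward the number of compound 1, but with chloro rather than fluoro the size is uncertain; a modest higher number is expected, a 2.5-fold higher number from compound 3 to compound 4 (0.40 log units; beyond the scatter). The estimate for compound 4 in this assay is 0.4 nM, expected to fall between 0.12 nM and 1.5 nM.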

Compound 4, inhibition constant: 0.342 nM
For compound 4 the middle estimate is 1.2-fold (0.07 log units) above the measured one, within the range that was stated.
By their numbers in this assay, from the lowest: compounds 2 and 3 (each within the scatter of the next); then compounds 4 and 1 (each within the scatter of the next).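

In this assay, chloro in place of fluoro on an aromatic carbon gives no readable change (a 1.8-fold lower number from compound 1 to compound 4 (0.27 log units; within the scatter)), so compound 4 and compound 1 cannot be told apart at this position. Replacing the 4-iodophenyl or the 4-bromophenyl on the amine nitrogen with 3-chlorophenyl does raise the number beyond the scatter (a 2.2-fold higher number from compound 3 to compound 4 (0.33 log units; beyond the scatter); a 4.1-fold higher number from compound 2 to compound 4 (0.61 log units; beyond the scatter)), and this now holds with a chloro group as well as a fluoro group on the aryl ring, although each of these steps changes both the halogen and the group name's ring number. Nothing measured here explains these steps.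

A 4-chlorophenyl or 3-bromophenyl group would separate the halogen from its ring number. On these data alone, how an unsubstituted phenyl or a 4-methoxyphenyl on the same nitrogen compares remains open.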